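This account rests on a few compounds, and the source may have more. Where it says the series, first, only, none or still open, it means among the compounds named here.

Measured compounds:
compound 1, `COc1cc(/C=C/C(=O)O[C@@H]2C[C@@](O)(CO)[C@H]3[C@H](O[C@@H]4O[C@H](CO)[C@@H](O)[C@H](O)[C@H]4O)OC=C[C@H]32)ccc1O` — 2000 nM
compound 2, `O=C(O[C@@H]1C[C@@](O)(CO)[C@H]2[C@H](O[C@@H]3O[C@H](CO)[C@@H](O)[C@H](O)[C@H]3O)OCC[C@H]21)c1ccc(O)cc1` — 39500 nM

For the measured compounds named here, in a functional assay for inhibition, read by fluorescence, with a stated time of 5 min, in the presence of a further agent that is not named here (on this read-out higher numbers stand for weaker inhibition and lower numbers for stronger inhibition), compound 2 gives 39500 nM, the highest of the two numbers known. Its nearest neighbour is compound 1, which in this assay gives 2000 nM, a lower number, and the gap between the two lies beyond the usual scatter. The two compounds differ in several places at once, so nothing further can be drawn from the pair about any single change.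

Compound 3, `C[C@]1(O)C[C@@H](OC(=O)c2ccc(O)cc2)[C@@H]2CCO[C@@H](O[C@@H]3O[C@H](CO)[C@@H](O)[C@H](O)[C@H]3O)[C@@H]21`, is not yet measured. Its difference from compound 2 is hydrogen in place of hydroxy on a saturated chain carbon bound to a saturated ring carbon. Going by the values given here, no single-change step between measured compounds is known, so the expectation rests on the size of the change alone: a small one, with no charge, ring or carbon count altered. The step of a 1.1-fold higher number from compound 2 to compound 3 (0.06 log units; within the scatter) is expected to be small, weakening if anything, and not beyond the scatter. Compound 3 is therefore estimated at 45000 nM, with a range from 15000 nM to 130000 nM.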

Compound 3, half-maximal inhibitory concentration: 8300 nM
Beside the measured number, compound 3's estimate is 5.4-fold (0.73 log units) above it, outside the stated range (below it).
By their numbers in this assay, from the lowest: compound 1; then compound 3; then compound 2.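

In this assay, for the compounds shown here, the change to hydrogen in place of hydroxy on a saturated chain carbon bound to a saturated ring carbon gives a 4.8-fold lower number from compound 2 to compound 3 (0.68 log units; beyond the scatter) as the first single-change step. This position is therefore not indifferent to substitution, and in this one pair, losing the hydroxy, or going from hydroxymethyl to methyl, goes with stronger inhibition. Nothing at hand explains this step.

Still open, on these data alone, is how an amine, a carboxylic acid or a longer chain at this place would compare with the hydroxymethyl of compound 2 and the methyl of compound 3. Also open, as far as these compounds go, is whether the same change on the core of compound 1 would give a step of similar direction and size.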